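The source may report more compounds than this note shows. Statements on the series, on what has been measured and on what is new or still open speak of the compounds shown alone.

- Compound 1 `O=C(Nc1ccccn1)c1cccc(Nc2ncc(F)c(Nc3ccc(F)cc3)n2)c1`: 15100 nM
- Compound 2 `O=C(Nc1cccc(Nc2ncc(F)c(Nc3ccc(F)cc3)n2)c1)c1ccncc1`: 4330 nM

Among the compounds with values here, in a functional assay on DU-145 cells (Homo sapiens) for antiproliferative activity, read by sulforhodamine B assay, with a stated time of 3 days (a lower number here means a stronger inhibitor of growth, a higher number a weaker inhibitor of growth), compound 1 gives 15100 nM, the higher of the two numbers so far. Compound 3 `COc1cc(NC(=O)c2cccc(Nc3ncc(F)c(Nc4ccc(F)cc4)n3)c2)cc(OC)c1` is not yet measured. It carries 3,5-dimethoxyphenyl in place of pyridin-2-yl on an amide-type nitrogen. Within the data shown here, only one measured step exists, a 3.5-fold lower number from compound 1 to compound 2 (0.54 log units; beyond the scatter). It is modest and comes from a different change, so it is a loose guide. A modest step to a lower number is therefore expected, though a result near compound 1 remains possible. For compound 3 the estimated value is 6000 nM, with an expected range of 1800 nM to 20000 nM. That estimate means a 2.5-fold lower number from compound 1 to compound 3 (0.40 log units; beyond the scatter).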

Compound 3, concentration for 50% growth inhibition: 13700 nM
For compound 3 the middle estimate is 2.3-fold (0.36 log units) below the measured one; measured number inside the range.
By their numbers in this assay, from the lowest: compound 2; then compounds 3 and 1 (each within the scatter of the next).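

On the amide-type nitrogen, 3,5-dimethoxyphenyl in place of pyridin-2-yl gives a 1.1-fold lower number from compound 1 to compound 3 (0.04 log units; within the scatter) in this assay, so the two compounds cannot be told apart. At this place, then, a ring of carbon only with two methoxy groups matches a pyridine ring with fewer heavy atoms, and the ring nitrogen of pyridin-2-yl is not needed for this level of growth inhibition. Nothing measured here offers a reason for this result.

On these data alone, whether a single methoxy group would behave like the pair remains open. So does the effect of an amine or a carboxylic acid on this ring.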